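Swapping isobutylamino for (carboxymethyl)amino on the chain

This account rests on a few compounds, and the source may have more. Where it says the series, first, only, none or still open, it means among the compounds named here.

Values in a functional assay on MCF7 cells (Homo sapiens) for antiproliferative activity (a lower number here means a stronger inhibitor, a higher number a weaker inhibitor), for the three measured compounds:
- Compound 1 `CC(C)=CCc1cc(C(=O)Nc2cc3ccc(OCCCN4CCCCC4)c(C)c3oc2=O)ccc1O` gives > 50000 nM (a limit of the assay, not a number)
- Compound 2 `CCCNCCCOc1ccc2cc(NC(=O)c3ccc(O)c(CC=C(C)C)c3)c(=O)oc2c1C` gives 980 nM
- Compound 3 `CC(C)=CCc1cc(C(=O)Nc2cc3ccc(OCCCNCC(C)C)c(C)c3oc2=O)ccc1O` gives 1320 nM

Going by the values given here, compound 3 has only one true number to stand against, and the two sit level (a 1.3-fold higher number from compound 2 to compound 3 (0.13 log units; within the scatter)). Compound 1 offers only a limit (the limit of > 50000 nM in this assay, at which 1 of the 3 values shown sits).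

Compound 4 `CC(C)=CCc1cc(C(=O)Nc2cc3ccc(OCCCNCC(=O)O)c(C)c3oc2=O)ccc1O` alters the end of the chain (carboxy in place of isopropyl on a saturated chain carbon bound to an amine nitrogen): carboxy in place of isopropyl on a saturated chain carbon bound to an amine nitrogen. Isobutylamino thus becomes (carboxymethyl)amino.

Two measured changes at this amine bear on the question. Adding a methyl on the chain barely registered, as the step above shows. Exchanging piperidin-1-yl for a small amino group had a large effect (an at least 51-fold lower number from compound 1 to compound 2 (1.70 log units; beyond the scatter); an at least 37-fold lower number from compound 1 to compound 3 (1.57 log units; beyond the scatter)). Among the compounds with values here, no measured compound carries a carboxy, so the size remains uncertain. Given the large swing from compound 1 (an at least 37-fold lower number from compound 1 to compound 3 (1.57 log units; beyond the scatter)), a step beyond the scatter in this assay seems likely here, towards a higher number and a weaker inhibitor. The expected change is moderate (a 4.5-fold higher number from compound 3 to compound 4 (0.66 log units; beyond the scatter)).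

Compound 4 is estimated at 6000 nM (range 1800 nM to 30000 nM)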

Compound 4, half-maximal inhibitory concentration: 18100 nM
The estimate for compound 4 lay 3.0-fold (0.48 log units) below the measured number; the range from low to high includes it.
By their numbers in this assay, from the lowest: compounds 2 and 3 (each within the scatter of the next); then compound 4. At a limit, above all of these: compound 1.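

In this assay, the end of this chain proves far less forgiving than the earlier methyl step suggested: carboxy in place of isopropyl gives a 14-fold higher number from compound 3 to compound 4 (1.14 log units; beyond the scatter), and carboxy in place of ethyl points the same way, with an 18-fold higher number from compound 2 to compound 4 (1.27 log units; beyond the scatter), even though the isopropyl that leaves and the carboxy that enters each count 3 heavy atoms. So at this saturated chain carbon bound to an amine nitrogen, the kind of atoms matters, not just the number of them, and a small amine end group alone does not secure a low number. Compound 4 still compares favourably with the piperidin-1-yl compound, with an at least 2.7-fold lower number from compound 1 to compound 4 (0.44 log units; beyond the scatter), but this step can only be read as a minimum, as compound 1 gives a limit and not a true number: the limit of > 50000 nM in this assay, at which 1 of the 4 values shown sits.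

The compounds shown cannot say why the carboxy costs so much, or whether the loss follows the carboxylic acid itself or its place on the chain. A methyl ester, a primary amide or a 2-hydroxyethyl group at the chain end, or a carboxylic acid on a longer chain, would help separate these readings.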